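The source may hold more compounds than are shown below. What is called first, only, known or untested is meant among the compounds shown, and "the series" means these compounds.

Measured in a toxicity assay on L02 cells (Homo sapiens) for cytotoxicity, read by MTT assay, with a stated time of 72 h; a lower number here means a stronger inhibitor, a higher number a weaker inhibitor:
- compound 1 `O=C1c2c[n+]([O-])c3ccccc3c2C(=O)c2c1c1ccccc1n2Cc1cn([C@@H]2C[C@H](O)[C@@H](CO)O2)nn1`: 630 nM
- compound 2 `O=C1c2c[n+]([O-])c3ccccc3c2C(=O)c2c1c1ccccc1n2Cc1cn(CC(O)CO)nn1`: 1070 nM
- compound 3 `CC1(C)O[C@@H](CO)[C@H](Cn2cc(Cn3c4c(c5ccccc53)C(=O)c3c[n+]([O-])c5ccccc5c3C4=O)nn2)O1`: 500 nM

Compound 3 stands level with compound 1, as the data show a 1.3-fold lower number from compound 1 to compound 3 (0.10 log units; within the scatter). Its separation from compound 2 is modest, with a 2.1-fold lower number from compound 2 to compound 3 (0.33 log units; beyond the scatter).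

Compound 4 `CC1(C)OC[C@@H](Cn2cc(Cn3c4c(c5ccccc53)C(=O)c3c[n+]([O-])c5ccccc5c3C4=O)nn2)O1` differs from compound 3 by a single change: 2,2-dimethyl-1,3-dioxolan-4-yl in place of 5-(hydroxymethyl)-2,2-dimethyl-1,3-dioxolan-4-yl on a saturated chain carbon bound to an aromatic nitrogen. Going by the values given here, no measured step isolates this change. The nearest evidence comes from the other exchanges of the group on the aromatic nitrogen, which also include a 1.7-fold higher number from compound 1 to compound 2 (0.23 log units; within the scatter). Across compounds 1, 2 and 3, therefore, quite different groups leave the numbers close together, and only the step to compound 3 from compound 2 passes the scatter, and then modestly. On that basis, no step beyond the scatter is expected in this assay, and neither direction is favoured. The expected change is a 1.1-fold higher number from compound 3 to compound 4 (0.04 log units; within the scatter). For compound 4 the estimated value is 550 nM, with an expected range of 250 nM to 1200 nM.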

Compound 4, half-maximal inhibitory concentration: 2900 nM
Compound 4: middle estimate off by 5.3-fold (0.72 log units), on the low side; the measured number lies above the stated range.
By their numbers in this assay, from the lowest: compounds 3, 1 and 2 (each within the scatter of the next, the first and the last beyond it); then compound 4.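

In this assay, going by these compounds alone, losing the hydroxymethyl from the 5-(hydroxymethyl)-2,2-dimethyl-1,3-dioxolan-4-yl group on a saturated chain carbon bound to an aromatic nitrogen gives a 5.8-fold higher number from compound 3 to compound 4 (0.76 log units; beyond the scatter), a larger step than any among the earlier compounds. The resulting 2,2-dimethyl-1,3-dioxolan-4-yl group also separates compound 4 from the other two, with a 2.7-fold higher number from compound 2 to compound 4 (0.43 log units; beyond the scatter) and a 4.6-fold higher number from compound 1 to compound 4 (0.66 log units; beyond the scatter), so this position is not as indifferent to change as those compounds suggested, and compound 4, the only one of the four without a hydroxyl on this group, has the highest number. No measurement available here accounts for this step.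

As far as these compounds go, whether the hydroxyl or the whole hydroxymethyl matters remains open. A methoxymethyl, methyl or aminomethyl group in place of the hydroxymethyl would help separate these possibilities.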